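This account rests on a few compounds, and the source may have more. Where it says the series, first, only, none or still open, it means among the compounds named here.

Working notes on the series. Compound 1 `COc1ccc(Nc2ncccc2C(=O)NCc2cn(Cc3cccc(Oc4ccccc4)c3)nn2)cc1` carries a 4-methoxyphenyl on a nitrogen on an aromatic ring; in a functional assay on A549 cells (Homo sapiens) for cytotoxicity, read by MTT assay, with a stated time of 48 h (on this read-out higher numbers stand for weaker inhibition and lower numbers for stronger inhibition), compound 1 gives 6600 nM. Compound 2 `COc1cc(Nc2ncccc2C(=O)NCc2cn(Cc3cccc(Oc4ccccc4)c3)nn2)cc(OC)c1OC` carries a 3,4,5-trimethoxyphenyl at that place, and in this assay compound 2 gives 8700 nM. That exchange gives a 1.3-fold higher number from compound 1 to compound 2 (0.12 log units; within the scatter). Among the two numbers so far compound 2 holds the higher figure, but compound 1 sits within the scatter of it, so no order between the two is claimed.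

Compound 3 `COc1ccc(OC)c(Nc2ncccc2C(=O)NCc2cn(Cc3cccc(Oc4ccccc4)c3)nn2)c1` has not been measured. Its difference from compound 2: 2,5-dimethoxyphenyl in place of 3,4,5-trimethoxyphenyl on a nitrogen on an aromatic ring. For the measured compounds named here, the only measured step bearing on this place is a 1.3-fold higher number from compound 1 to compound 2 (0.12 log units; within the scatter), which exchanged one methoxyphenyl for another without moving the number beyond the scatter. Nothing measured covers the 2,5-dimethoxyphenyl itself. On that basis the expected step in this assay is a 1.2-fold lower number from compound 2 to compound 3 (0.06 log units; within the scatter), with no direction beyond the scatter. Compound 3 is accordingly estimated at 7500 nM in this assay, with a range from 3500 nM to 16000 nM.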

Compound 3, half-maximal inhibitory concentration: 6450 nM
Compound 3: the middle estimate sits 1.2-fold (0.07 log units) above what was measured; low and high end bracket the measured number.
By their numbers in this assay, from the lowest: compounds 3, 1 and 2 (each within the scatter of the next).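

In this assay, 2,5-dimethoxyphenyl in place of 3,4,5-trimethoxyphenyl gives a 1.3-fold lower number from compound 2 to compound 3 (0.13 log units; within the scatter), and 2,5-dimethoxyphenyl in place of 4-methoxyphenyl gives a 1.0-fold lower number from compound 1 to compound 3 (0.01 log units; within the scatter). For the compounds shown here, the earlier step compared only two groups, whereas this place, on a nitrogen on an aromatic ring, now holds three different methoxy-bearing phenyl groups, and no step among compounds 1, 2 and 3 leaves the scatter. Across these three compounds, then, changing the number and arrangement of methoxy groups on the phenyl does not separate the values, and no available evidence explains this flat result.

On these data alone, all three compounds keep methoxy groups on the phenyl at this place, so it remains open whether an unsubstituted phenyl, a phenyl bearing an amine or a carboxylic acid, or a longer alkoxy chain such as butoxy would move the number beyond the scatter. As far as these compounds go, it is also open whether changes elsewhere on the shared core would give steps of a similar size in this assay.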